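A few compounds are considered here, and "the series" means these few. Any claim that something is new, unique, unknown or untested is made for them only; others in the source may bear on it.

Measured compounds:
- compound 1, `O=C(/C=C/c1ccc([N+](=O)[O-])cc1)Nc1cc(Sc2ncn[nH]2)c(O)c2ccccc12` — in a functional assay on MDA-MB-231 cells (Homo sapiens) for antiproliferative activity, read by MTT assay, with a stated time of 48 h (a lower number here means a stronger inhibitor, a higher number a weaker inhibitor), compound 1 gives > 100000 nM, which is a limit of the assay and not a number.
- compound 2, `O=C(Nc1cc(Sc2ncn[nH]2)c(O)c2ccccc12)c1ccc([N+](=O)[O-])cc1` — in this assay compound 2 gives > 100000 nM, again a limit of the assay and not a number.

Compound 2 therefore stands at the edge of what this assay can report: both values shown sit at the limit of > 100000 nM in this assay, at which 2 of the 2 values shown sit, so nothing separates compound 2 from compound 1 on the numbers available, and no ordering between them can be stated.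

Compound 3, `O=C(Nc1cc(Sc2ncn[nH]2)c(O)c2ccccc12)c1cccc([N+](=O)[O-])c1`, has not been measured in this assay. It differs from compound 2 in a single place: 3-nitrophenyl in place of 4-nitrophenyl on a carbonyl carbon. Among the measured compounds shown here, no step between measured compounds is available to calibrate what such a change does here. Since compound 2 gives only a limit in this assay, the expectation for compound 3 is a step of a number no higher from compound 2 to compound 3 (the limit leaves the size open), which is to say none beyond the scatter. Compound 3 is accordingly expected to give about 100000 nM in this assay, with an estimated range from 30000 nM to 300000 nM, and most likely to be reported as a limit as well.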

Compound 3, half-maximal inhibitory concentration: 48000 nM
Compound 3: the middle estimate sits 2.1-fold (0.32 log units) above what was measured; the measured number falls inside the stated range.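

In this assay, 3-nitrophenyl in place of 4-nitrophenyl on a carbonyl carbon gives an at least 2.0-fold lower number from compound 2 to compound 3 (0.31 log units; beyond the scatter) and so provides the only step among the compounds shown that can be read. The change therefore matters at this position: the two groups have the same atoms and the same counts of donors and acceptors, yet only compound 3 gives a number rather than a limit of the assay. From the compounds shown here alone, only the minimum size of this step is known, and its true size stays open because the value of compound 2 is a limit and not a number: the limit of > 100000 nM in this assay, at which 2 of the 3 values shown sit.

The compounds shown leave open whether this lower number is tied to the nitro group itself or would also appear with another group on the phenyl ring, such as an amine or a carboxylic acid. They also do not show how a longer chain on the carbonyl carbon, in place of the 3-nitrophenyl, would read in this assay on the shared core.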